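From a Fluorophenyl to an Aminoethyl Group on Sulfur

This account rests on a few compounds, and the source may have more. Where it says the series, first, only, none or still open, it means among the compounds named here.

Of the compounds shown here, three that share a common core have been measured in an ADME assay on microsomes from liver (Rattus norvegicus) for metabolic stability, with a stated time of 10 min; on this read-out higher numbers stand for a more stable compound and lower numbers for a less stable compound. Compound 1 `Cc1ccccc1S(=O)(=O)NC(=O)c1ccc(Nc2nc(NC3(c4ccc(Cl)cc4)CC3)nc(OCC(F)(F)F)n2)cc1` gives 100% in this assay. Compound 3 `O=C(NS(=O)(=O)c1ccc(F)cc1)c1ccc(Nc2nc(NC3(c4ccc(Cl)cc4)CC3)nc(OCC(F)(F)F)n2)cc1`, which carries a 4-fluorophenyl in place of 2-methylphenyl on a sulfonyl sulfur, gives 99%; the step of a number 1 percentage points lower from compound 1 to compound 3 (within the scatter) is within the scatter, so the two cannot be told apart. Compound 2 `CCCCCNc1nc(Nc2ccc([N+](=O)[O-])cc2)nc(OCC(F)(F)F)n1`, built differently in several places, gives 35%, far below both. Compound 3 thus sits with compound 1 at the top of the numbers seen so far, with compound 2 a long way beneath.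

Going by the values given here, compound 4 `CC(C)NCCS(=O)(=O)NC(=O)c1ccc(Nc2nc(NC3(c4ccc(Cl)cc4)CC3)nc(OCC(F)(F)F)n2)cc1` is the next compound, and its only difference from compound 3 is 2-(isopropylamino)ethyl in place of 4-fluorophenyl on a sulfonyl sulfur. Among the compounds with values here, the one measured step at this position, from compound 1 to compound 3, exchanged one aromatic ring for another and stayed within the scatter. Within the data shown here, no measured step exchanges an aromatic ring for a chain with a hydrogen-bond donor here, so the evidence for this step is thin. A drop is therefore expected to be possible but not large, with the step of a number 14 percentage points lower from compound 3 to compound 4 (beyond the scatter) estimated. Compound 4 is expected to give about 85%, within a range from 55% to 100%.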

Compound 4, percent of the compound remaining: 100%
Estimate against measurement, compound 4: 15 percentage points below; the range from low to high includes it.
By their numbers in this assay, from the lowest: compound 2; then compounds 3, 1 and 4 (each within the scatter of the next).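

In this assay, putting 2-(isopropylamino)ethyl on the sulfonyl sulfur gives a number 1 percentage points higher from compound 3 to compound 4 (within the scatter), and measured against the other aromatic group it gives no change at the digits printed from compound 1 to compound 4 (within the scatter). The earlier pair compared only one aromatic ring with another, whereas these steps show that a chain with no ring, carrying a nitrogen with a hydrogen-bond donor, cannot be told apart from either ring on this read-out, so among these three compounds the group on this sulfur leaves the percentage remaining within the scatter. Nothing available explains this result.

On these data alone, all three compounds sit close to the top of the scale, so this read-out has little room to separate them, and it remains open whether a carboxylic acid, a primary amine or a longer chain on the same sulfur would also match them. Compound 2 differs from them in several places, so the compounds shown also leave open which part of the shared core of compounds 1, 3 and 4 goes with their higher numbers.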